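Swapping the aryl group on the piperazine ring

The compounds below may be only part of what the source reports. "The series", "measured", "known", "first", "only" and "open" are said of these compounds alone.

Measured compounds:
compound 1, `COc1ccccc1N1CCN(CCNc2cc(-c3ccccc3)nn(C)c2=O)CC1`, 2.01 nM
compound 2, `COc1ccc(Cl)cc1N1CCN(CCNc2c(C(C)=O)c(-c3ccccc3)nn(C)c2=O)CC1`, 3.95 nM
compound 3, `COc1ccc(Cl)cc1N1CCN(CCCNc2cc(-c3ccccc3)nn(C)c2=O)CC1`, 2.01 nM

In an assay on isolated protein for binding affinity to Alpha-1B adrenergic receptor (Homo sapiens), read by radioligand binding (on this read-out higher numbers stand for weaker inhibition and lower numbers for stronger inhibition), compound 2 shows the highest of the three numbers, yet its distance to compound 1 and to compound 3 is the same in each case and lies within the scatter of repeated measurements, so the three compounds cannot be told apart on these data. For the measured compounds named here, no pair among them differs in only one place, so no single-point step is available as a guide.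

Compound 4, `CC(=O)c1c(-c2ccccc2)nn(C)c(=O)c1NCCN1CCN(c2ccccc2F)CC1`, keeps the core of compound 2 and changes only the group on the piperazine nitrogen: 2-fluorophenyl in place of 5-chloro-2-methoxyphenyl on an amine nitrogen in a ring. Going by the values given here, no measured pair in this set isolates a change of that kind, so the expectation rests on the general closeness of the three values. The estimate is that compound 4 will give a somewhat higher number than compound 2, with a step of a 2.5-fold higher number from compound 2 to compound 4 (0.40 log units; beyond the scatter) that is expected to sit near the edge of the scatter rather than clearly beyond it. Compound 4 is accordingly expected to give about 10 nM in this assay, with a likely range from 3 nM to 40 nM.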

Compound 4, inhibition constant: 3.77 nM
For compound 4 the middle estimate is 2.7-fold (0.42 log units) above the measured one; measured number inside the range.
By their numbers in this assay, from the lowest: compounds 1, 3, 4 and 2 (each within the scatter of the next).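

For the compounds shown here, this pair gives the first single-place comparison in the set: in this assay, putting 2-fluorophenyl in place of 5-chloro-2-methoxyphenyl on the amine nitrogen in a ring gives a 1.0-fold lower number from compound 2 to compound 4 (0.02 log units; within the scatter), so the two compounds cannot be told apart. On the core of compound 2, this position therefore accepts an exchange in which the aryl group goes from 9 heavy atoms to 7 and from 1 hydrogen-bond acceptor to 0, with no readable difference in this read-out. The data offer no evidence on why the exchange leaves the number within the scatter.

The compounds shown leave open whether a plain phenyl, a pyridyl or a cyclohexyl group on that nitrogen would also stay within the scatter, since a single pair cannot show how far this tolerance extends. They also leave open whether 2-fluorophenyl would behave in the same way on the core of compound 1, which lacks the acetyl group of compound 2, or with the longer chain of compound 3.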